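Chloro-to-fluoro swap on the tetrasubstituted aryl ring

The source may hold more compounds than are shown below. What is called first, only, known or untested is meant among the compounds shown, and "the series" means these compounds.

Measured compounds:
- compound 1, `N#Cc1c(F)c(Cl)c(C(C(=O)c2ccccc2)=C2NCCN2)c(C#N)c1F`: 32.6 ug/mL
- compound 2, `N#Cc1c(F)c(F)c(C(C(=O)c2ccccc2)=C2NCCN2)c(C#N)c1F`: 9.1 ug/mL
- compound 3, `N#Cc1c(F)c(Cl)c(C(C(=O)c2ccc(F)cc2)=C2NCCCCN2)c(C#N)c1F`: 27.8 ug/mL

Three compounds of the series have numbers in a functional assay on HepG2 cells (Homo sapiens) for antiproliferative activity, read by MTT assay; a higher number here means a weaker inhibitor, a lower number a stronger inhibitor. Compound 1 gives 32.6 ug/mL and compound 2 gives 9.1 ug/mL; compound 3 gives 27.8 ug/mL, and its number sits closest to compound 1, within the scatter of it, while it stands apart from compound 2.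

Compound 1 and compound 2 differ in one place: fluoro in place of chloro on an aromatic carbon. This brought a 3.6-fold lower number from compound 1 to compound 2 (0.55 log units; beyond the scatter) in this assay.

Compound 4, `N#Cc1c(F)c(F)c(C(C(=O)c2ccc(F)cc2)=C2NCCCCN2)c(C#N)c1F`, is not yet measured. It differs from compound 3 in one place: fluoro in place of chloro on an aromatic carbon. This is the same kind of change as that from compound 1 to compound 2, made on a different core; how the core of compound 3 differs from the core of compound 1 is not broken down here. The surroundings of the changed carbon are the same in both pairs.

Among the compounds with values here, for compound 4 in this assay a step of about a 3.6-fold lower number from compound 3 to compound 4 (0.56 log units; beyond the scatter) is expected, resting on the single earlier instance of this change, a 3.6-fold lower number from compound 1 to compound 2 (0.55 log units; beyond the scatter), and on the closeness of compound 3 to compound 1 in this assay. Compound 4 is accordingly estimated at 7.7 ug/mL, with a plausible range from 3.8 ug/mL to 16 ug/mL.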

Compound 4, half-maximal inhibitory concentration: 24.9 ug/mL
Compound 4: middle estimate off by 3.2-fold (0.51 log units), on the low side, outside the stated range (above it).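

On the core of compound 3, fluoro in place of chloro on an aromatic carbon reads in this assay as a 1.1-fold lower number from compound 3 to compound 4 (0.05 log units; within the scatter), so the step seen on the core of compound 1 does not recur there at comparable size. The two instances of the same change therefore disagree, even though the surroundings of the changed carbon are the same in both pairs: the same change on two cores in this assay, a 3.6-fold lower number (0.55 log units; beyond the scatter) from compound 1 to compound 2 and a 1.1-fold lower number (0.05 log units; within the scatter) from compound 3 to compound 4, 3.2-fold (0.51 log units) apart, beyond the scatter of two such steps

This shows that, in this series, the size of the step cannot simply be carried from one core to another, but it does not show which feature of the cores matters, since the core of compound 3 differs from the core of compound 1 in more than one place and two pairs cannot separate those differences or predict the step on a third core.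

Still open, going by these compounds, is whether a core carrying only one of the differences between compound 1 and compound 3 would show the larger step or the smaller one. Also open, on these data alone, is where bromo, methoxy or a plain hydrogen at the changed carbon would fall on each core in this assay.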